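A few compounds are considered here, and "the series" means these few. Any claim that something is new, unique, unknown or untested is made for them only; others in the source may bear on it.

In a functional assay on DU-145 cells (Homo sapiens) for cytotoxicity, read by MTT assay, with a stated time of 72 h (a lower number here means that less compound is needed, a higher number that more compound is needed for the effect), compound 1 `O=c1cc(NC2CCCCC2)cc(/C=C/c2ccccc2)o1` gives 1.23 uM, which shows that the shared core can reach low values. Compound 2 `COc1ccc(Nc2cc(C)oc(=O)c2)cc1` carries other groups on that core. Compound 2 gives > 30 uM, which is a limit of the assay and not a number. So compound 2 stands at the limit of > 30 uM in this assay, at which 1 of the 2 values shown sits.

Compound 3 `COc1ccc(Nc2cc(C(C)C)oc(=O)c2)cc1` changes compound 2 in one place: isopropyl in place of methyl on an aromatic carbon. This puts isopropyl in place of methyl on an aromatic carbon, next to the ring oxygen. Among the compounds with values here, no pair of measured compounds differs by this swap alone, so the size of its effect cannot be read from the data. Compound 1, at 1.23 uM, differs from compound 2 in more than one place, so it offers only a loose hint that a lower reading is possible. The expected change is an at least 1.5-fold lower number from compound 2 to compound 3 (0.17 log units; that floor lies within the scatter), a modest move towards less compound being needed, and another limit would be no surprise. For compound 3 the estimated value is 20 uM, with an expected range from 7 uM to 45 uM.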

Compound 3, concentration for half-maximal effect: > 30 uM
Compound 3: no number, only a limit; the forecaster's own chance of this, stated with the estimate: 50%; at least 1.5-fold (0.17 log units) between middle value and limit.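

In this assay compound 3 gives > 30 uM, which is a limit of the assay and not a number. Within the data shown here, compound 2 is also recorded only as a limit, so no step between compound 2 and compound 3 can be read: the limit of > 30 uM in this assay, at which 2 of the 3 values shown sit. The compounds shown leave open whether isopropyl in place of methyl changes the value at all, and by how much.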